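From an aryl amide to a small hydroxyalkyl amide

A few compounds are considered here, and "the series" means these few. Any claim that something is new, unique, unknown or untested is made for them only; others in the source may bear on it.

Compound 2 `CCn1c(C(=O)Nc2ccc(OC(F)(F)F)cc2)ccc1C(CC)(CC)c1ccc(OCCC(O)(CC)CC)c(C)c1` is measured in an assay on cells for agonist activity at vitamin D3 receptor (Homo sapiens), with a stated time of 96 h (a lower number here means that less compound is needed, a higher number that more compound is needed for the effect), where compound 2 reaches only the limit > 10000 nM, a limit rather than a number. Compound 1 `C#CCCOC(=O)c1ccc(C(CC)(CC)c2ccc(OCCC(O)(CC)CC)c(C)c2)n1CC` gives 6030 nM in this assay, and the step of an at least 1.6-fold higher number from compound 1 to compound 2 (0.21 log units; that floor lies within the scatter) is the only one measured; it lies at the limit of > 10000 nM in this assay, at which 1 of the 2 values shown sits, and does not touch the amide nitrogen. Compound 3 `CCn1c(C(=O)NC(C)CO)ccc1C(CC)(CC)c1ccc(OCCC(O)(CC)CC)c(C)c1` differs from compound 2 by 1-(hydroxymethyl)ethyl in place of 4-(trifluoromethoxy)phenyl on an amide-type nitrogen. Among the compounds with values here, no measured step bears on this change, so compound 3 is expected near where compound 2 stands, with an at least 1.1-fold lower number from compound 2 to compound 3 (0.04 log units; that floor lies within the scatter), and an estimated value of 9000 nM between 2500 nM and 30000 nM.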

Compound 3, half-maximal effective concentration: 96 nM
Beside the measured number, compound 3's estimate is 94-fold (1.97 log units) above it, and the stated range ends above it.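

On an amide-type nitrogen, the group carried matters greatly in this assay: 1-(hydroxymethyl)ethyl in place of 4-(trifluoromethoxy)phenyl gives an at least 100-fold lower number from compound 2 to compound 3 (2.01 log units; beyond the scatter). Putting (1-(hydroxymethyl)ethyl)amino in place of (but-3-yn-1-yl)oxy on the carbonyl carbon also gives a 63-fold lower number from compound 1 to compound 3 (1.80 log units; beyond the scatter). Compound 2 stands at a limit rather than a number, so its step is only a floor: the limit of > 10000 nM in this assay, at which 1 of the 3 values shown sits.

Going by these compounds, what remains open is which change counts: the loss of the ring, the fewer heavy atoms or the hydroxyl group. A plain isopropyl group, or an amine or carboxylic acid in place of that hydroxyl, would help separate these.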